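The source may report more compounds than this note shows. Statements on the series, on what has been measured and on what is new or still open speak of the compounds shown alone.

Working notes on the series. Compound 1 `ClCc1ccc(Cn2cnc3c(Cl)ncnc32)cc1` is the parent; in a functional assay on NCI-H460 cells (Homo sapiens) for cytotoxicity, read by sulforhodamine B assay, with a stated time of 48 h (on this read-out lower numbers stand for higher toxicity in this test and higher numbers for lower toxicity in this test), compound 1 gives 26900 nM. Compound 2 `Nc1nc(Cl)c2ncn(Cc3ccc(CCl)cc3)c2n1` carries the change amino in place of hydrogen on an aromatic carbon on the core of compound 1, and in this assay compound 2 gives 63100 nM. The resulting step is a 2.3-fold higher number from compound 1 to compound 2 (0.37 log units; beyond the scatter), a shift toward lower toxicity in this assay that is beyond the scatter but modest.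

Compound 3 `ClCc1ccccc1Cn1cnc2c(Cl)ncnc21` has the same atoms as compound 1, joined differently; the difference between the two cores is not broken down here. In this assay compound 3 reaches only the limit of the assay, > 100000 nM, so no number is known for it. That limit is the limit of > 100000 nM in this assay, at which 1 of the 3 values shown sits.

Compound 4 `Nc1nc(Cl)c2ncn(Cc3ccccc3CCl)c2n1` is not yet measured in this assay. Among the compounds with values here, it stands to compound 3 as compound 2 stands to compound 1: the change is amino in place of hydrogen on an aromatic carbon, the same change as the one made from compound 1 to compound 2, at a place described in the same words. Within the data shown here, the expectation for compound 4 rests on the one measured instance of this change, a 2.3-fold higher number from compound 1 to compound 2 (0.37 log units; beyond the scatter), which moved the number upward, and on compound 3 already sitting at the limit of > 100000 nM in this assay, at which 1 of the 3 values shown sits. The step in this assay is expected to be a step that the limit leaves unreadable from compound 3 to compound 4, of the same kind as the earlier one, which would carry the number further beyond the limit rather than back under it. Compound 4 is thus expected to give 200000 nM in this assay, with a range of 100000 nM to 500000 nM, and most likely the assay again reports only a limit for compound 4.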

Compound 4, concentration lethal to 50% of the cells: > 100000 nM
Compound 4: a limit, no number; the forecaster's own chance of this, stated with the estimate: 85%; the middle value does not contradict the limit.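

In this assay, within the data shown here, compound 3 and compound 4 both give only a limit, so no step between them can be read, because the two compounds sit at the same limit: the limit of > 100000 nM in this assay, at which 2 of the 4 values shown sit. The compounds shown leave open whether amino in place of hydrogen on an aromatic carbon changes the number on the core of compound 3 at all, so the only readable instance of this change remains that from compound 1 to compound 2.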